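This account rests on a few compounds, and the source may have more. Where it says the series, first, only, none or still open, it means among the compounds named here.

Measured so far in a functional assay on NCI-H23 cells (Homo sapiens) for inhibition, read by sulforhodamine B assay, with a stated time of 48 h; a higher number here means a weaker inhibitor of growth, a lower number a stronger inhibitor of growth:
compound 1 `CN1CCN(CCCOc2cccc3nc(Nc4ccc(Cl)c(F)c4)ccc23)CC1` gives 1750 nM;
compound 2 `CN1CCN(CCCOc2cccc3nc(Nc4cc(Cl)cc(Cl)c4)ccc23)CC1` gives 1720 nM.

Compound 2 sits together with compound 1, the step of a 1.0-fold lower number from compound 1 to compound 2 (0.01 log units; within the scatter) being within the scatter, so the two cannot be told apart. Compound 3 `CN1CCN(CCCOc2cccc3nc(Nc4cccc(Cl)c4)ccc23)CC1` differs from compound 2 by hydrogen in place of chloro on an aromatic carbon, the 3,5-dichlorophenyl becoming 3-chlorophenyl. Among the compounds with values here, the one measured step, a 1.0-fold lower number from compound 1 to compound 2 (0.01 log units; within the scatter), exchanged one substituted phenyl for another with no shift beyond the scatter; no step removes a single chloro alone. Compound 3 is therefore expected to stay close, with a step of a 1.3-fold higher number from compound 2 to compound 3 (0.11 log units; within the scatter) in this assay. The estimate for compound 3 is 2200 nM, between 1000 nM and 5000 nM.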

Compound 3, concentration for 50% growth inhibition: 2270 nM
Beside the measured number, compound 3's estimate is 1.0-fold (0.01 log units) below it, and the stated range covers the measured number.
By their numbers in this assay, from the lowest: compounds 2, 1 and 3 (each within the scatter of the next).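

In this assay, hydrogen in place of one chloro of the 3,5-dichlorophenyl gives a 1.3-fold higher number from compound 2 to compound 3 (0.12 log units; within the scatter), so this chloro can go without a shift beyond the scatter. Likewise, 3-chlorophenyl in place of 4-chloro-3-fluorophenyl gives a 1.3-fold higher number from compound 1 to compound 3 (0.11 log units; within the scatter), so the three substituted phenyl groups cannot be told apart here. Nothing available gives a reason for this. Still open, on these data alone, is whether the last chloro matters: a plain phenyl would test that. So would a methoxy group or a carboxylic acid on this ring, which would show whether a group other than halogen shifts the number.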